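Bromo in Place of Thiophen-3-yl: a Cytotoxicity Estimate

The source may hold more compounds than are shown below. What is called first, only, known or untested is meant among the compounds shown, and "the series" means these compounds.

Compound 1, `Cc1cc(-c2cccc(C#N)c2)cn2c(CSCCc3ccccc3)cnc12`, in an ADME assay on HEL cells (Homo sapiens) for cytotoxicity, with a stated time of 3 days (on this read-out lower numbers stand for higher toxicity in this test and higher numbers for lower toxicity in this test), gives > 100 ug/mL, a limit of the assay.
Compound 2, `COc1ccc(-c2cc(C)c3ncc(CSCCc4ccccc4)n3c2)cc1`, in this assay gives 20 ug/mL.
Compound 3, `Cc1cc(-c2ccsc2)cn2c(CSCCc3ccccc3)cnc12`, in this assay gives >= 4 ug/mL, also a limit of the assay.

Compound 3 thus stands only at a limit, so its place among the three measured compounds cannot be read off. Going by the values given here, the one readable step is an at least 5.0-fold lower number from compound 1 to compound 2 (0.69 log units; beyond the scatter); the steps a step that the two limits leave unreadable from compound 1 to compound 3 and a step that the limit leaves unreadable from compound 2 to compound 3 remain unreadable, since the limit of > 100 ug/mL in this assay, at which 1 of the 3 values shown sits, and the limit of >= 4 ug/mL in this assay, at which 1 of the 3 values shown sits, cut them off. Compound 4 is `Cc1cc(Br)cn2c(CSCCc3ccccc3)cnc12`. The change from compound 3 is bromo in place of thiophen-3-yl on an aromatic carbon. Among the compounds with values here, none of the measured steps swaps an aromatic ring for a single halogen atom, so no measured step bears directly on this change, and the only firm point of departure is the limit of compound 3. No direction beyond the scatter is therefore expected. The expected step is a step that the limit leaves unreadable from compound 3 to compound 4, and compound 4 is estimated at 30 ug/mL, in the range from 6 ug/mL to 100 ug/mL.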

Compound 4, minimum cytotoxic concentration: >= 2 ug/mL
Compound 4 ended at the assay's limit; the forecaster's own chance of this, stated with the estimate: 40%; the middle value does not contradict the limit.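

In this assay, compound 4 stands only at a limit of the assay, so its steps from compound 1, compound 2 and compound 3 cannot be read. The compounds shown leave open whether bromo in place of thiophen-3-yl changes the cytotoxicity read-out at all, and in which direction.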